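Notes on a nitrile-bearing aryl amine antiproliferative series

The compounds below may be only part of what the source reports. "The series", "measured", "known", "first", "only" and "open" are said of these compounds alone.

Measured so far:
Compound 1 `CCN(c1ccc(C#N)c(Cl)c1)c1cc(-c2cccs2)ccc1C` — > 30000 nM
Compound 2 `N#Cc1ccc(N2CCc3cc(-c4cncnc4)ccc3C2)cc1C(F)(F)F` — "not determined" (no result reported)
Compound 3 `Cn1nccc1-c1cccc2c1CCCN2c1ccc(C#N)c(C(F)(F)F)c1` — 9800 nM

In a functional assay on PC-3 cells (Homo sapiens) for antiproliferative activity, read by CCK-8 assay, with a stated time of 6 days (a lower number here means a stronger inhibitor, a higher number a weaker inhibitor), compound 1 gives > 30000 nM, which is a limit of the assay and not a number. Compound 2 has no result in this assay; compound 2 reports "not determined" (no result reported). Compound 3 gives 9800 nM in this assay and is the only one of the three with a single number. Compound 1 thus stands at the limit, as recorded in the limit of > 30000 nM in this assay, at which 1 of the 3 values shown sits, and its place relative to compound 3 can be stated only as lying beyond the measured range. No pair of these compounds differs in one place, so no measured step within the set is available.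

Compound 4 `CCN(c1ccc(C#N)c(Cl)c1)c1cc(-n2cnc3ccccc32)ccc1C` is the untested analogue of compound 1. The change is 1H-benzimidazol-1-yl in place of thiophen-2-yl on an aromatic carbon. Because compound 1 sits at > 30000 nM the step cannot be bounded from the measured side. A step from compound 1 to compound 4 of an at least 2.0-fold lower number from compound 1 to compound 4 (0.30 log units; that floor lies within the scatter) is expected, a gain somewhat beyond the scatter but uncertain in both direction and size. Compound 4 is expected to give 15000 nM in this assay, with a range from 4000 nM to 60000 nM.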

Compound 4, half-maximal inhibitory concentration: 8160 nM
The estimate for compound 4 lay 1.8-fold (0.26 log units) above the measured number; measured number inside the range.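

Among these compounds, compound 4 provides the first comparison across a single place: in this assay, 1H-benzimidazol-1-yl in place of thiophen-2-yl, on the aromatic carbon para to a methyl group, gives an at least 3.6-fold lower number from compound 1 to compound 4 (0.56 log units; beyond the scatter). That step has a floor and no upper bound, because compound 1 carries a limit of the assay and not a number: the limit of > 30000 nM in this assay, at which 1 of the 4 values shown sits. The position therefore admits a change that brings the read-out within the measured range, but the entering group differs in several ways at once, with more heavy atoms, an added six-membered aromatic ring of carbon only, and nitrogen in place of sulfur, and this single step cannot separate those differences.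

The compounds shown leave open whether the added ring or the ring nitrogens carry the step, a question that 1H-imidazol-1-yl on the same carbon would address. Also open, on these data alone, are how an amine or a carboxylic acid at this position would read in this assay and whether the step would carry over to the cores of compound 2 and compound 3.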